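Shortening the chain of compound 1

The compounds below may be only part of what the source reports. "The series", "measured", "known", "first", "only" and "open" are said of these compounds alone.

In a functional assay on ACHN cells (Homo sapiens) for antiproliferative activity, read by sulforhodamine B assay (on this read-out higher numbers stand for weaker inhibition of growth and lower numbers for stronger inhibition of growth), compound 1 (`CCCCCCOc1cccc(O)c1C(=O)/C=C/c1ccc(O)cc1`) gives > 30000 nM, which is a limit and not a number. Compound 2 (`CC(C)=CCOc1cccc(O)c1C(=O)/C=C/c1ccc(O)cc1`) gives > 30000 nM, also a limit. Both stand at the limit of > 30000 nM in this assay, at which 2 of the 3 values shown sit, and between them lies a step that the two limits leave unreadable from compound 1 to compound 2. Compound 3 (`O=C(/C=C/c1ccc(O)cc1)c1c(O)cccc1OCC1CCCC1`) gives a true number, 3510 nM. The measured steps to it are an at least 8.5-fold lower number from compound 1 to compound 3 (0.93 log units; beyond the scatter) and an at least 8.5-fold lower number from compound 2 to compound 3 (0.93 log units; beyond the scatter).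

Compound 4 (`CCCCOc1cccc(O)c1C(=O)/C=C/c1ccc(O)cc1`) shortens the chain of compound 1: hydrogen in place of ethyl on a saturated chain carbon, four bonds along the chain from an oxygen on an aromatic ring. Among the compounds with values here, no measured step shortens a chain, so the steps to compound 3 bear on this change only indirectly. They show that changing this group can move the result, but compound 2 shows that a change can also leave it at the limit. A modest move toward lower numbers is expected, though compound 4 may well remain at the limit. The expected step is an at least 1.5-fold lower number from compound 1 to compound 4 (0.17 log units; that floor lies within the scatter), and it is very uncertain. For compound 4 the estimated value is 20000 nM, with an expected range from 6000 nM to 60000 nM.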

Compound 4, concentration for 50% growth inhibition: > 30000 nM
Compound 4: no number, only a limit (the forecaster's own chance of this, stated with the estimate: 55%); middle value at least 1.5-fold (0.17 log units) from the limit.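

Shortening the chain of compound 1 brings no readable change in this assay: compound 4 stands at a limit, as compound 1 and compound 2 do, so the steps from those two to it cannot be read. Replacing the cyclopentyl group with a propyl group gives an at least 8.5-fold higher number from compound 3 to compound 4 (0.93 log units; beyond the scatter), so this shorter open chain does not match the ring on the same chain carbon. Only compound 3 gives a true number, which leaves the other compounds with no order among themselves: the limit of > 30000 nM in this assay, at which 3 of the 4 values shown sit.

How much chain length matters therefore stays open, since the limit hides any difference among the open chains shown. Also open, going by these compounds, is whether another ring in the same place, such as a cyclohexyl or cyclobutyl group, would give a number as low as that of compound 3 or lower.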